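The compounds below may be only part of what the source reports. "The series", "measured", "known", "first", "only" and "open" are said of these compounds alone.

Of the compounds shown here, three sharing one core have been measured in a functional assay (Oryctolagus cuniculus) for inhibition of platelet-activating factor receptor (Cavia porcellus); on this read-out higher numbers stand for weaker inhibition and lower numbers for stronger inhibition. Compound 1 `CCCCCCCCCC(=O)OCC1CN(C(=O)c2cc(OC)c(OC)c(OC)c2)CCN1C(=O)c1cc(OC)c(OC)c(OC)c1` gives 2820 nM. Compound 2 `COc1cc(C(=O)N2CCN(C(=O)c3cc(OC)c(OC)c(OC)c3)C(COC(=O)NC(C)(C)C)C2)cc(OC)c1OC` gives 130 nM, and compound 3 `COc1cc(C(=O)N2CCN(C(=O)c3cc(OC)c(OC)c(OC)c3)C(COC(=O)NC(C)C(C)C)C2)cc(OC)c1OC` gives 80 nM, the lowest of the three numbers, although its gap to compound 2 lies within the scatter. Replacing the nonyl ester by a carbamate that carries a hydrogen-bond donor brought a 22-fold lower number from compound 1 to compound 2 (1.34 log units; beyond the scatter) and a 35-fold lower number from compound 1 to compound 3 (1.55 log units; beyond the scatter), whereas swapping one branched alkyl for another produced only a 1.6-fold lower number from compound 2 to compound 3 (0.21 log units; within the scatter).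

Compound 4 `CCCCN(CCCC)C(=O)OCC1CN(C(=O)c2cc(OC)c(OC)c(OC)c2)CCN1C(=O)c1cc(OC)c(OC)c(OC)c1` takes the step (dibutylamino in place of (1,2-dimethylpropyl)amino on a carbonyl carbon); the entering group carries no hydrogen-bond donor. For the measured compounds named here, the steps that bear on this are the two large ones, because a 22-fold lower number from compound 1 to compound 2 (1.34 log units; beyond the scatter) and a 35-fold lower number from compound 1 to compound 3 (1.55 log units; beyond the scatter) both accompanied the arrival of a donor-bearing carbamate, and compound 4 gives that donor up again while keeping the carbamate. A step toward higher numbers, beyond the scatter but short of the ester of compound 1, is therefore anticipated.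

For compound 4 the expected step is a 6.3-fold higher number from compound 3 to compound 4 (0.80 log units; beyond the scatter).

Compound 4 is accordingly estimated at 500 nM, within a range from 150 nM to 2000 nM.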

Compound 4, half-maximal inhibitory concentration: 1250 nM
For compound 4 the middle estimate is 2.5-fold (0.40 log units) below the measured one; measured number inside the range.
By their numbers in this assay, from the lowest: compounds 3 and 2 (each within the scatter of the next); then compound 4; then compound 1.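

With dibutylamino on the carbonyl carbon, this assay shows a 16-fold higher number from compound 3 to compound 4 (1.19 log units; beyond the scatter) and a 9.6-fold higher number from compound 2 to compound 4 (0.98 log units; beyond the scatter), so at this position the number depends strongly on the amine part of the carbamate and not only on the carbamate's presence. The carbamate without a hydrogen-bond donor recovers little of the earlier gain, with only a 2.3-fold lower number from compound 1 to compound 4 (0.35 log units; beyond the scatter) relative to the nonyl ester. Because this change removes the donor while also raising the group from 6 to 9 heavy atoms, the two differences cannot be separated here, and no supporting evidence bears on the shift.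

On these data alone, whether the donor or the size of the group matters more stays open. Butylamino, which keeps the donor on a single chain, and dimethylamino, which lacks it with shorter chains, would address that question.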